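Cyano in Place of Hydroxy on the Piperidine Ring

The source may hold more compounds than are shown below. What is called first, only, known or untested is meant among the compounds shown, and "the series" means these compounds.

Compound 1 `O=C(Nc1ccnnc1)c1cc(N2CCCC2)ccc1OCc1ccccc1`: 20 nM
Compound 2 `C[C@@H]1CN(c2ccc(OCc3ccccc3)c(C(=O)Nc3ccnnc3)c2)C[C@H](C)O1`: 20 nM
Compound 3 `O=C(Nc1ccnnc1)c1cc(N2CCC(O)CC2)ccc1OCc1ccccc1`: 39.8 nM

All three share one core and differ only in the amine on the aromatic carbon, measured in an assay on Sf9 cells for inhibition of Leucine-rich repeat serine/threonine-protein kinase 2 (Homo sapiens), read by TR-FRET, with stated times of 30 min and 2 h; on this read-out higher numbers stand for weaker inhibition and lower numbers for stronger inhibition. Compound 3 carries the 4-hydroxypiperidin-1-yl group; the steps leading to it, a 2.0-fold higher number from compound 1 to compound 3 (0.30 log units; within the scatter) and a 2.0-fold higher number from compound 2 to compound 3 (0.30 log units; within the scatter), lie within the scatter, as does no change at the digits printed from compound 1 to compound 2 (within the scatter). Compound 4 `N#CC1CCN(c2ccc(OCc3ccccc3)c(C(=O)Nc3ccnnc3)c2)CC1` differs from compound 3 by cyano in place of hydroxy on a saturated ring carbon. Among the compounds with values here, no measured step touches this position directly; the three steps only show that exchanging the whole amine leaves this assay essentially unchanged. On that basis no step beyond the scatter is expected for compound 4: a 1.1-fold lower number from compound 3 to compound 4 (0.06 log units; within the scatter). Compound 4 is therefore estimated at 35 nM, within 15 nM to 90 nM.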

Compound 4, half-maximal inhibitory concentration: 10 nM
Estimate against measurement, compound 4: 3.5-fold (0.54 log units) above; the whole stated range lies above it.
By their numbers in this assay, from the lowest: compounds 4, 1, 2 and 3 (each within the scatter of the next, the first and the last beyond it).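

Within the data shown here, at this saturated ring carbon, the exchange of hydroxy for cyano gives the first step beyond the scatter (a 4.0-fold lower number from compound 3 to compound 4 (0.60 log units; beyond the scatter)), so in this assay this single position registers a change that the exchanges of whole amines did not. Against the other amines, the 4-cyanopiperidin-1-yl group stays within the scatter (a 2.0-fold lower number from compound 2 to compound 4 (0.30 log units; within the scatter); a 2.0-fold lower number from compound 1 to compound 4 (0.30 log units; within the scatter)). Nothing measured here accounts for the step. The compounds shown leave open whether a carboxamide, a carboxylic acid or a cyanomethyl chain on this carbon would give a similar number.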